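The source may report more compounds than this note shows. Statements on the series, on what has been measured and on what is new or still open speak of the compounds shown alone.

Measured so far:
compound 1, `CC(C)(C)C(=O)CN1C(=O)N(CC(=O)Nc2cccc(O)c2)N=C(C2CCCCC2)c2ccccc21`: 27.5 nM
compound 2, `CC(C)(C)C(=O)CN1C(=O)N(CC(=O)Nc2cccc(-n3ccnc3)c2)N=C(C2CCCCC2)c2ccccc21`: 871 nM

In a functional assay on stomach for binding affinity to Gastrin/cholecystokinin type B receptor (Rattus norvegicus) (a higher number here means weaker binding, a lower number tighter binding), compound 1 gives 27.5 nM, while compound 2 gives 871 nM, the higher of the two numbers. For the measured compounds named here, the single measured step, a 32-fold higher number from compound 1 to compound 2 (1.50 log units; beyond the scatter), is the only guide available. Compound 3, `CN(C)c1cccc(NC(=O)CN2N=C(C3CCCCC3)c3ccccc3N(CC(=O)C(C)(C)C)C2=O)c1`, differs from compound 2 by dimethylamino in place of 1H-imidazol-1-yl on an aromatic carbon. Going by the values given here, no measured pair shows this exact exchange, but removing the 1H-imidazol-1-yl group undoes the change that took compound 1 to compound 2. Because a 32-fold higher number from compound 1 to compound 2 (1.50 log units; beyond the scatter) was large, taking that group away may recover part of the lost ground, though dimethylamino is not hydroxy and brings no hydrogen-bond donor. Compound 3 is therefore expected to fall between the two measured values, an estimated 4.4-fold lower number from compound 2 to compound 3 (0.64 log units; beyond the scatter) in this assay. The estimated value for compound 3 is 200 nM, within a range of 50 nM to 800 nM.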

Compound 3, dissociation constant: 91.2 nM
Compound 3: middle estimate off by 2.2-fold (0.34 log units), on the high side; low and high end bracket the measured number.
By their numbers in this assay, from the lowest: compound 1; then compound 3; then compound 2.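

In this assay, the move to dimethylamino gives a 9.6-fold lower number from compound 2 to compound 3 (0.98 log units; beyond the scatter) and so wins back most of the ground lost with 1H-imidazol-1-yl, although neither group has a hydrogen-bond donor. The absence of a donor on this aromatic carbon therefore does not by itself set the number reached by compound 2. Hydroxy still keeps an edge, with a 3.3-fold higher number from compound 1 to compound 3 (0.52 log units; beyond the scatter) on exchange for dimethylamino, so the group at this place continues to matter even among the smaller substituents. Nothing measured here accounts for these differences. From the compounds shown here alone, it remains open whether a primary amine or a methoxy group at this place would come closer to compound 1 than compound 3 does. Going by these compounds, how a carboxylic acid or a longer chain ending in an amine would fare also remains unknown.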